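Inverting one ring stereocentre of compound 2

The compounds below may be only part of what the source reports. "The series", "measured", "known", "first", "only" and "open" are said of these compounds alone.

In an ADME assay on microsomes from liver (Mus musculus) for metabolic stability, read by LC-MS, with a stated time of 30 min, tested at 1 uM (on this read-out higher numbers stand for a more stable compound and lower numbers for a less stable compound), compound 1 (`CC(C)C1=C(C(=O)N2[C@H](C)CC[C@H]2C(=O)N2CCN(C)CC2)SC2=N[C@@](C)(c3ccc(Cl)cc3)[C@@H](c3ccc(Cl)cc3)N21`) gives 25% and compound 2 (`CC(=O)N1CCN(C(=O)[C@@H]2CC[C@@H](C)N2C(=O)C2=C(C(C)C)N3C(=N[C@@](C)(c4ccc(Cl)cc4)[C@H]3c3ccc(Cl)cc3)S2)C[C@H]1C`) gives 55%, the higher of the two numbers. Compound 3 (`CC(=O)N1CCN(C(=O)[C@@H]2CC[C@@H](C)N2C(=O)C2=C(C(C)C)N3C(=N[C@@](C)(c4ccc(Cl)cc4)[C@H]3c3ccc(Cl)cc3)S2)C[C@@H]1C`) departs from compound 2 as follows: the two compounds have the same atoms and bonds and differ only in configuration as drawn: 1 of 5 stereo elements differ; a stereocentre at a saturated ring carbon is drawn R in compound 2 and S in compound 3. Going by the values given here, the only measured step, a number 30 percentage points higher from compound 1 to compound 2 (beyond the scatter), replaces a group on a carbonyl carbon and leaves the configuration question untested. It therefore gives no direct guide to size or direction, and no shift beyond the scatter is assumed. The expected change is a number 5 percentage points lower from compound 2 to compound 3 (within the scatter). For compound 3 the estimated value is 50%, with an expected range of 30% to 68%.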

Compound 3, percent of the compound remaining: 65%
For compound 3 the middle estimate is 15 percentage points below the measured one; the range from low to high includes it.
By their numbers in this assay, from the lowest: compound 1; then compounds 2 and 3 (each within the scatter of the next).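

In this assay the inversion at this saturated ring carbon gives a number 10 percentage points higher from compound 2 to compound 3 (within the scatter) and so shows no effect of the configuration there beyond the scatter. With the S centre, the larger group on the carbonyl carbon still gives a number 40 percentage points higher from compound 1 to compound 3 (beyond the scatter) and so the rise seen with the R centre is not tied to that drawing. The pair tests this one centre alone: the fact that compounds 2 and 3 differ only in the configuration as drawn.

Open, going by these compounds, is whether an ethyl or hydroxymethyl group on this ring carbon would behave alike. Also open, on these data alone, is what inverting any other stereocentre would do.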